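A few compounds are considered here, and "the series" means these few. Any claim that something is new, unique, unknown or untested is made for them only; others in the source may bear on it.

Compound 1 `O=C(Nc1ccccc1)C1CCN(C/C=C/c2ccccc2)CC1`: 57900 nM
Compound 2 `COc1ccc(NC(=O)C2CCN(C/C=C/c3ccccc3)CC2)cc1`: 58200 nM

In a functional assay on MGC-803 cells (Homo sapiens) for inhibition, read by MTT assay, with a stated time of 72 h (on this read-out lower numbers stand for stronger inhibition and higher numbers for weaker inhibition), compound 2 at 58200 nM lies within the scatter of compound 1. Compound 3 `COc1ccccc1NC(=O)C1CCN(C/C=C/c2ccccc2)CC1` differs from compound 2 as follows: 2-methoxyphenyl in place of 4-methoxyphenyl on an amide-type nitrogen. Among the measured compounds shown here, only one measured step bears on this change, a 1.0-fold higher number from compound 1 to compound 2 (0.00 log units; within the scatter), where methoxy replaced hydrogen on an aromatic carbon. For the measured compounds named here, no measured compound carries the 2-methoxyphenyl group, so the evidence is thin, and no shift beyond the scatter is expected in this assay. The expected change is a 1.1-fold lower number from compound 2 to compound 3 (0.05 log units; within the scatter). Compound 3 is estimated at 52000 nM, with an expected range of 22000 nM to 100000 nM.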

Compound 3, half-maximal inhibitory concentration: 71200 nM
Compound 3: middle estimate off by 1.4-fold (0.14 log units), on the low side; low and high end bracket the measured number.
By their numbers in this assay, from the lowest: compounds 1, 2 and 3 (each within the scatter of the next).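

In this assay, 2-methoxyphenyl in place of 4-methoxyphenyl on the amide-type nitrogen gives a 1.2-fold higher number from compound 2 to compound 3 (0.09 log units; within the scatter), and methoxy in place of hydrogen gives a 1.2-fold higher number from compound 1 to compound 3 (0.09 log units; within the scatter). Thus, both methoxyphenyl groups shown on this nitrogen stay within the scatter of compound 1, so the choice between them shows no measurable difference here. No measurement shown offers an explanation for this result. The compounds shown leave open whether an amine or a carboxylic acid on the phenyl ring would give a step beyond the scatter.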